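Hydrazone aryl swap: furan-2-yl to 4-fluorophenyl

The source may report more compounds than this note shows. Statements on the series, on what has been measured and on what is new or still open speak of the compounds shown alone.

The series shares one core, seen in compound 1 `Cc1c(C(=O)N/N=C\c2cc([N+](=O)[O-])ccc2O)oc2cccc(O)c12`, compound 2 `Cc1c(C(=O)N/N=C\c2ccco2)oc2cccc(O)c12`, compound 3 `Cc1c(C(=O)N/N=C\c2ccccn2)oc2cccc(O)c12` and the still unmeasured compound 4 `Cc1c(C(=O)N/N=C\c2ccc(F)cc2)oc2cccc(O)c12`; the four differ only in the aryl group on the carbon with a double bond to nitrogen. In a functional assay on PC-3 cells (Homo sapiens) for inhibition (a lower number here means a stronger inhibitor, a higher number a weaker inhibitor), compound 1 gives 17100 nM. For compound 2 the assay reports only a limit, >= 40000 nM, not a number. Compound 3 likewise reaches only a limit, >= 40000 nM. Among the measured compounds shown here, the one measured step, a step that the two limits leave unreadable from compound 2 to compound 3, has no readable size because both of its ends sit at the limit of >= 40000 nM in this assay, at which 2 of the 3 values shown sit. Compound 2 thus stands at the edge of the range shown, with no number of its own.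

Compound 4 differs from compound 2 by 4-fluorophenyl in place of furan-2-yl on a carbon with a double bond to nitrogen. For the measured compounds named here, no measured step bears directly on this change, and the only step measured in this assay, a step that the two limits leave unreadable from compound 2 to compound 3, offers no direction. The expected step of an at least 1.1-fold lower number from compound 2 to compound 4 (0.05 log units; that floor lies within the scatter) is therefore none beyond the scatter. Compound 4 is estimated at 35000 nM, with a range from 15000 nM to 80000 nM. A limit rather than a number is again the more likely report.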

Compound 4, half-maximal inhibitory concentration: >= 40000 nM
Compound 4: a limit, no number (the forecaster's own chance of this, stated with the estimate: 60%); middle value at least 1.1-fold (0.05 log units) from the limit.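

In this assay compound 4 gives only a limit, >= 40000 nM, not a number. No step from compound 2 or compound 3 to compound 4 can be read: the limit of >= 40000 nM in this assay, at which 3 of the 4 values shown sit.

The compounds shown leave open how compound 2, compound 3 and compound 4 rank among themselves, and how far each lies from compound 1.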